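The source may report more compounds than this note shows. Statements on the series, on what has been measured and on what is new or still open speak of the compounds shown alone.

For the measured compounds named here, in a functional assay on HUVEC cells (Homo sapiens) for antiproliferative activity, with a stated time of 3 days (on this read-out higher numbers stand for weaker inhibition and lower numbers for stronger inhibition), compound 3 (`CO[C@@H]1[C@H](OC(=O)N[C@@H](C(N)=O)C(C)C)CC[C@](O)(CCl)[C@H]1[C@@]1(C)O[C@@H]1CC=C(C)C`) gives 0.15 nM, the only true number so far. Compound 1 (`CO[C@@H]1[C@H](OC(=O)N[C@@H](C(N)=O)C(C)C)CC[C@]2(O)CO[C@](C)([C@H](O)CC=C(C)C)[C@@H]12`) reads > 30000 nM, which is a limit of the assay and not a number. Compound 2 (`CO[C@@H]1[C@H](OC(=O)N[C@@H](C(N)=O)C(C)C)CC[C@@]2(O)CO[C@](C)([C@H](O)CC=C(C)C)[C@@H]12`) reads > 30000 nM, again a limit. Going by the values given here, all that separates this pair is the fact that compounds 1 and 2 differ only in the configuration as drawn, and between them lies a step that the two limits leave unreadable from compound 1 to compound 2, so no measured step gives a size for the change ahead.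

Compound 4 (`C=C([C@H](O)CC=C(C)C)[C@H]1[C@H](OC)[C@H](OC(=O)N[C@@H](C(N)=O)C(C)C)CC[C@]1(O)CCl`) has the same atoms as compound 3, joined differently: a group of 9 heavy atoms (8 carbon, 1 oxygen; no ring) in place of a group of 9 heavy atoms (8 carbon, 1 oxygen; one three-membered non-aromatic ring with 1 hetero atom), on a saturated ring carbon. On a saturated ring carbon, the 2-methyl-3-(3-methylbut-2-en-1-yl)oxiran-2-yl group gives way to a group with no ring and a second double bond. Among the compounds with values here, compound 3 at 0.15 nM has much room to lose, so weaker inhibition in this assay is expected, although this is a judgement with no measured step behind it. The estimated change is a 330-fold higher number from compound 3 to compound 4 (2.52 log units; beyond the scatter), and it is deliberately uncertain. For compound 4 the estimate is 50 nM, with an expected range of 1 nM to 5000 nM.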

Compound 4, half-maximal inhibitory concentration: 3.3 nM
Compound 4: the middle estimate sits 15-fold (1.18 log units) above what was measured; measured number inside the range.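

In this assay, for the compounds shown here, replacing the 2-methyl-3-(3-methylbut-2-en-1-yl)oxiran-2-yl group on this saturated ring carbon with the open group that has no ring and a second double bond gives a 22-fold higher number from compound 3 to compound 4 (1.34 log units; beyond the scatter), the first step here with a readable size. The three-membered ring therefore matters to the number, yet it is not required for a measurable effect, since compound 4 without it still gives a true value of 3.3 nM. The earlier step between compound 1 and compound 2 could show nothing of this size, because it cannot be read: the limit of > 30000 nM in this assay, at which 2 of the 4 values shown sit.

From the compounds shown here alone, whether an aziridine ring, with nitrogen in place of the ring oxygen, or a saturated chain at this carbon would stand closer to compound 3 or to compound 4 remains open. The compounds shown also do not tell why this step is so large.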